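Replacing the catechol ester on the shared core

The compounds below may be only part of what the source reports. "The series", "measured", "known", "first", "only" and "open" are said of these compounds alone.

Compound 1 `CC(C)=CCC/C(C)=C/C[C@@H]1C[C@]2(CC=C(C)C)C(=O)[C@@](CC=C(C)C)(C(=O)C(C(=O)c3ccc(O)c(OC(=O)CCCC[C@@H]4SCC5NC(=O)NC54)c3)=C2O)[C@@]1(C)CCC=C(C)C`: 11300 nM
Compound 2 `CC(C)=CCC/C(C)=C/C[C@@H]1C[C@]2(CC=C(C)C)C(=O)[C@@](CC=C(C)C)(C(=O)C(OC(=O)c3ccc(O)c(O)c3)=C2O)[C@@]1(C)CCC=C(C)C`: 13100 nM

Both values come from a functional assay on A549 cells (Homo sapiens) for inhibition, read by MTT assay, with a stated time of 72 h; on this read-out higher numbers stand for weaker inhibition and lower numbers for stronger inhibition. On this assay, compound 2 at 13100 nM and compound 1 at 11300 nM lie within the scatter of each other, so compound 2 stands level with compound 1 on these two numbers. Compound 3 `CC(C)=CCC/C(C)=C/C[C@@H]1C[C@]2(CC=C(C)C)C(=O)[C@@](CC=C(C)C)(C(=O)C(Cc3ccc(O)c(O)c3)=C2O)[C@@]1(C)CCC=C(C)C` is still unmeasured. Its change from compound 2 is 3,4-dihydroxybenzyl in place of ((3,4-dihydroxyphenyl)carbonyl)oxy on a double-bonded ring carbon, on a double-bonded ring carbon of a six-membered non-aromatic ring of carbon only. Within the data shown here, no measured step covers this exchange, so the data give no direct guide to its size or direction. The only anchors are the two values above, and no shift beyond the scatter is expected. The estimated step is a 1.2-fold lower number from compound 2 to compound 3 (0.08 log units; within the scatter), which is expected to stay within the scatter. For compound 3 the estimated value is 11000 nM, with an expected range from 4500 nM to 27000 nM.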

Compound 3, half-maximal inhibitory concentration: > 20000 nM
Compound 3: no number, only a limit (the forecaster's own chance of this, stated with the estimate: 10%); middle value at least 1.8-fold (0.25 log units) away from the limit.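

In this assay, compound 3 has no number, only a limit: the limit of > 20000 nM in this assay, at which 1 of the 3 values shown sits. This gives the series its first step at this ring carbon, an at least 1.5-fold higher number from compound 2 to compound 3 (0.18 log units; that floor lies within the scatter). Since that figure is only a floor and the floor lies within the scatter, the result does not show whether the change moves the value beyond the scatter, only that any real shift from this exchange would run towards weaker inhibition. The 3,4-dihydroxyphenyl ring is present in both compounds, so the step belongs to the exchange of the ester link for the benzyl link, not to any change in that ring.

On these data alone, the true size of the step remains open. Also open, as far as these compounds go, is how an amide link in place of the ester, or an amine or a carboxylic acid on this ring carbon, would read.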